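A few compounds are considered here, and "the series" means these few. Any claim that something is new, unique, unknown or untested is made for them only; others in the source may bear on it.

Of the compounds shown here, three share a core and have been measured in an assay on cells with Cystic fibrosis transmembrane conductance regulator variant F508del (Homo sapiens) as the target, read by fluorescence, with stated times of 24 h and 30 min; on this read-out lower numbers stand for an effect already at smaller amounts and higher numbers for an effect only at larger amounts of compound. Compound 1, with the structure `NC(=O)CN1CCN(c2nc(-c3cccnc3)nc3c2CN(Cc2ccccc2)CC3)CC1`, gives 100000 nM. Compound 2, with the structure `CC(=O)NCCCNc1nc(-c2ccccn2)nc2c1CN(Cc1ccc(F)cc1)CC2`, gives 200 nM in this assay. Compound 3, with the structure `CN(C)CCN1CCN(c2nc(-c3ccccn3)nc3c2CN(C(=O)c2ccccc2)CC3)CC1`, gives 100000 nM in this assay.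

Compound 3 thus stands level with compound 1 at the digits reported, the two together giving the highest numbers of the three; the gap between them lies within the scatter, so no order can be drawn. Compound 2 stands furthest from compound 3, with a lower number in this assay, a gap well beyond the scatter.

Compound 4, with the structure `CN(C)CCN1CCN(c2nc(-c3ccccn3)nc3c2CN(S(=O)(=O)c2ccccc2)CC3)CC1`, has not yet been measured. It differs from compound 3 in one place: phenylsulfonyl in place of benzoyl on an amine nitrogen in a ring. Among the compounds with values here, no measured pair in this set carries a change of this kind, so there is nothing to read the size of the step from. With compound 3 already at the high end of the numbers seen, the expectation is a step of no change at the digits printed from compound 3 to compound 4 (within the scatter), that is, none beyond the scatter. Compound 4 is therefore expected to give about 100000 nM in this assay, within a range from 25000 nM to 300000 nM.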

Compound 4, half-maximal effective concentration: 100000 nM
Estimate against measurement, compound 4: no gap at the digits printed, within the range that was stated.
By their numbers in this assay, from the lowest: compound 2; then compounds 1, 3 and 4 (each within the scatter of the next).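

In this assay, within the data shown here, phenylsulfonyl in place of benzoyl on an amine nitrogen in a ring gives no change at the digits printed from compound 3 to compound 4 (within the scatter), the first step in this set that can be read at this position. The exchange keeps the six-membered aromatic ring of carbon only and brings more heavy atoms and more hydrogen-bond acceptors than benzoyl, yet with the rest of compound 3 held the read-out stays within the scatter. Nothing measured here bears on why the two groups read alike.

Compounds 3 and 4 leave open whether a urea or a simple ethyl group on that nitrogen, with the rest of compound 3 kept, would give a lower number in this assay. As far as these compounds go, it also remains open whether the exchange of benzoyl for phenylsulfonyl would read the same on a compound with a lower number, such as compound 2 at 200 nM, since that compound carries a different group on this nitrogen and differs in other places too.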